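Fluorophenyl thioether isomers on a benzamide anilide scaffold

The compounds below may be only part of what the source reports. "The series", "measured", "known", "first", "only" and "open" are said of these compounds alone.

Measured so far in a functional assay on HCT-116 cells (Homo sapiens) for antiproliferative activity, read by CCK-8 assay, with a stated time of 72 h; on this read-out lower numbers stand for stronger inhibition and higher numbers for weaker inhibition:
compound 1 `Nc1ccccc1NC(=O)c1ccc(CSc2nccc(C(F)(F)F)n2)cc1` gives 1140 nM
compound 2 `Nc1ccccc1NC(=O)/C=C/c1ccc(CSc2ccc(F)cc2)cc1` is recorded as "not determined" (no result reported)
compound 3 `Nc1ccccc1NC(=O)c1ccc(CSc2cccc(F)c2)cc1` gives 2870 nM

Compound 3 carries the highest number of the two reported. Its nearest neighbour is compound 1, whose number is lower by a gap that lies beyond the usual scatter. Compound 2 contributes no number, so nothing can be said of it.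

The next entry is compound 4 `Nc1ccccc1NC(=O)c1ccc(CSc2ccc(F)cc2)cc1`. It differs from compound 3 by 4-fluorophenyl in place of 3-fluorophenyl on a sulfur. Going by the values given here, no measured pair shows the effect of moving the fluorine between these two ring positions, so there is no direct guide for the size of the step.

With a change this small in the counted atoms, the step from compound 3 to compound 4 is expected to be a 1.1-fold lower number from compound 3 to compound 4 (0.06 log units; within the scatter), that is, no change beyond the scatter in either direction. Compound 4 is therefore estimated at 2500 nM, with a range from 1000 nM to 6500 nM.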

Compound 4, half-maximal inhibitory concentration: 4010 nM
Compound 4: middle estimate off by 1.6-fold (0.21 log units), on the low side; measured number inside the range.
By their numbers in this assay, from the lowest: compound 1; then compounds 3 and 4 (each within the scatter of the next).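

In this assay, going by these compounds alone, the pair gives the first direct reading at this place, on a sulfur whose other neighbour is a saturated chain carbon: a 1.4-fold higher number from compound 3 to compound 4 (0.15 log units; within the scatter) for 4-fluorophenyl in place of 3-fluorophenyl. The two compounds hold the same atoms, joined differently, and this change of fluorine position does not separate them on this read-out, so the pair gives no sign that the choice between these two ring positions matters here. No measurement at hand offers an explanation for this result.

The step between compound 4 and compound 2 cannot be read, as compound 2 has no reported result. As far as these compounds go, it remains open whether an unsubstituted phenyl, a methoxy group or a carboxylic acid on this ring would move the number beyond the scatter.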